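A few compounds are considered here, and "the series" means these few. Any claim that something is new, unique, unknown or untested is made for them only; others in the source may bear on it.

The account begins with compound 3 `Cc1cccc(C#Cc2ccc3c(n2)CCN(C2CCCC2)C3=O)c1`, which in a functional assay on HEK293 cells for positive allosteric modulation of metabotropic glutamate receptor 5 (Homo sapiens), read by FLIPR and calcium flux (on this read-out higher numbers stand for an effect only at larger amounts of compound and lower numbers for an effect already at smaller amounts), gives 7.5 nM. Among the numbers obtained so far it stands lowest. Its nearest neighbour is compound 1 `O=C(NC1CCCC1)c1ccc(C#Cc2ccccc2)nc1`, which in this assay gives 19 nM, a gap that lies beyond the scatter. Compound 2 `O=C(NC1CCCC1)c1ccc(C#Cc2cccnc2)nc1` in this assay reaches only a limit of the assay, > 10000 nM, and (the limit of > 10000 nM in this assay, at which 1 of the 3 values shown sits).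

Compound 4 `O=C1c2ccc(C#Cc3cccnc3)nc2CCN1C1CCCC1` is the next member in line. It differs from compound 3 by a single exchange: pyridin-3-yl in place of 3-methylphenyl on a triple-bonded carbon. Among the compounds with values here, one measured step bears directly on this exchange, an at least 520-fold higher number from compound 1 to compound 2 (2.72 log units; beyond the scatter), and it is the same replacement on the same kind of carbon, differing only in the core that carries it. That step was large and went toward higher numbers, to the point of leaving only a limit. On that basis a large rise in the number for compound 4 is expected in this assay, in the same direction, and a limit rather than a value is considered the more likely outcome. The step from compound 3 expected is a 400-fold higher number from compound 3 to compound 4 (2.60 log units; beyond the scatter). For compound 4 the estimate in this assay is 3000 nM, with a range from 200 nM to 10000 nM.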

Compound 4, half-maximal effective concentration: 748 nM
Estimate against measurement, compound 4: 4.0-fold (0.60 log units) above, within the range that was stated.
By their numbers in this assay, from the lowest: compound 3; then compound 1; then compound 4. At a limit, above all of these: compound 2.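

In this assay, the exchange of a carbon-only aromatic ring for pyridin-3-yl on a triple-bonded carbon now has a size that can be read: a 100-fold higher number from compound 3 to compound 4 (2.00 log units; beyond the scatter). The earlier pair gave no such size, and its step stands only as a bound, as compound 2 is a limit of the assay: the limit of > 10000 nM in this assay, at which 1 of the 4 values shown sits. The new pair shows that the exchange raises the number on a second core as well, with no pair shown going against this, and that a compound carrying pyridin-3-yl at this place can still return a true value, as compound 4 does with 748 nM.

As far as these compounds go, the two pairs do not start from the same group, phenyl in compound 1 and 3-methylphenyl in compound 3, so what the methyl group contributes on its own stays open, as does how much of the change in each pair belongs to the ring nitrogen alone. Also open, from the compounds shown here alone, is how other groups on the triple-bonded carbon would behave, such as pyridin-2-yl, a methyl-bearing pyridine or 3-fluorophenyl.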